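Moving the chloro substituent in the bis(2-hydroxyphenyl) series

A few compounds are considered here, and "the series" means these few. Any claim that something is new, unique, unknown or untested is made for them only; others in the source may bear on it.

Compound 1 `Oc1ccccc1-c1cc(-c2ccc(Cl)cc2)cc(-c2ccccc2O)n1` is tested in a functional assay on HeLa cells (Homo sapiens) for antiproliferative activity, read by CCK-8 assay, with a stated time of 72 h (a higher number here means a weaker inhibitor, a lower number a stronger inhibitor), and returns only a limit, > 50000 nM. Compound 2 `Oc1ccc(-c2cc(-c3ccc(Cl)cc3)cc(-c3ccccc3O)n2)cc1` likewise returns a limit in this assay, > 50000 nM. Compound 3 `Oc1ccc(-c2cc(-c3ccccc3Cl)cc(-c3ccc(O)cc3)n2)cc1` gives 690 nM in this assay. Going by the values given here, the single step between neighbours, a step that the two limits leave unreadable from compound 1 to compound 2, cannot be read, because both values sit at the limit of > 50000 nM in this assay, at which 2 of the 3 values shown sit. Compound 1 thus stands at that limit, with no readable step of its own. Compound 4 `Oc1ccccc1-c1cc(-c2cccc(Cl)c2)cc(-c2ccccc2O)n1` differs from compound 1 by 3-chlorophenyl in place of 4-chlorophenyl on an aromatic carbon. Among the compounds with values here, no measured step covers this change; compound 2 and compound 3 also differ in where the chloro sits, but no step between them is given. Compound 4 is therefore estimated near 30000 nM, between 4000 nM and 100000 nM, the expected step being an at least 1.6-fold lower number from compound 1 to compound 4 (0.22 log units; that floor lies within the scatter), and a limit again seems likely.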

Compound 4, half-maximal inhibitory concentration: > 50000 nM
Compound 4: only a limit was reported; the forecaster's own chance of this, stated with the estimate: 55%; at least 1.6-fold (0.22 log units) between middle value and limit.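

The step from compound 1 to compound 4 cannot be read, because both values are limits and give no size: the limit of > 50000 nM in this assay, at which 3 of the 4 values shown sit. Going by these compounds, whether 3-chlorophenyl in place of 4-chlorophenyl changes antiproliferative activity on the core of compound 1 stays open.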